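Trading a methyl for hydrogen on the sulfonyl phenyl

This account rests on a few compounds, and the source may have more. Where it says the series, first, only, none or still open, it means among the compounds named here.

Of the compounds shown here, two have been measured in an assay on isolated protein (Cavia porcellus) with cysteinyl leukotriene receptor (Homo sapiens) as the target; a higher number here means a more potent compound, by a factor of ten per unit of this negative logarithm, a lower number a less potent compound. Compound 1 `COc1cc(C(=O)NS(=O)(=O)c2ccccc2)ccc1Cc1cn(C)c2ccc(NC(=O)OC3CCCC3)cc12` gives 9.69 in this assay. Compound 2 `COc1cc(C(=O)NS(=O)(=O)c2ccccc2C)ccc1Cc1cn(C)c2ccc(NC(=O)CC3CCCC3)cc12` gives 9.64 in this assay, and this value sits within the usual scatter of the value of compound 1, so the two cannot be told apart on these numbers. Compound 3 `COc1cc(C(=O)NS(=O)(=O)c2ccccc2)ccc1Cc1cn(C)c2ccc(NC(=O)CC3CCCC3)cc12` has not been measured. It differs from compound 2 in one place: hydrogen in place of methyl on an aromatic carbon, ortho to a large group; the same change read one bond further out turns 2-methylphenyl into phenyl. Compound 3 shares its phenylsulfonyl part with compound 1 and the rest of its structure with compound 2. With both measured values so close, a step in this assay no larger than the scatter is expected in either direction. Compound 3 is therefore expected to give about 9.65 in this assay, with a range from 9.25 to 10.05, which means an expected step of a number 0.01 log units higher from compound 2 to compound 3 (within the scatter).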

Compound 3, negative logarithm of the antagonist equilibrium constant: 9.8
The estimate for compound 3 lay 0.15 log units below the measured number; measured number inside the range.
By their numbers in this assay, from the lowest: compounds 2, 1 and 3 (each within the scatter of the next).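

Each single change can now be read alone. Compounds 1 and 2 differ in two places and did not allow this. In this assay the 2-methylphenyl group can be exchanged for phenyl with only a small step (a number 0.16 log units higher from compound 2 to compound 3 (within the scatter)), so the methyl ortho to a large group can be present or absent without a step beyond the scatter. Cyclopentylmethyl in place of cyclopentyloxy on the carbonyl carbon likewise stays within the scatter (a number 0.11 log units higher from compound 1 to compound 3 (within the scatter)), and no accompanying measurement is available to explain either result.

Still open, from the compounds shown here alone, is whether chlorine, methoxy or trifluoromethyl in place of this methyl would also stay within the scatter. The same question applies to a longer chain or an amine in place of the cyclopentylmethyl group.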